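Sulfamoyl for methylsulfonyl on a tetrahydronaphthalene sulfone series

The compounds below may be only part of what the source reports. "The series", "measured", "known", "first", "only" and "open" are said of these compounds alone.

Compound 1 `O=C(NC[C@@H]1CCCc2cc(S(=O)(=O)c3cccc(F)c3)ccc21)c1ncc[nH]1` and compound 2 `CS(=O)(=O)NC[C@@H]1CCCc2cc(S(=O)(=O)c3cccc(F)c3)ccc21` share a core and differ only at the amine nitrogen. In an assay on isolated protein for displacement of a labelled ligand from 5-hydroxytryptamine receptor 6 (Homo sapiens) (on this read-out lower numbers stand for stronger inhibition and higher numbers for weaker inhibition), compound 1 gives 15.9 nM, whereas compound 2 gives 0.2 nM; the step of an 80-fold lower number from compound 1 to compound 2 (1.90 log units; beyond the scatter) is beyond the scatter, and compound 2 therefore holds the lowest number of the two measured.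

Compound 3 `NS(=O)(=O)NC[C@@H]1CCCc2cc(S(=O)(=O)c3cccc(F)c3)ccc21` keeps the sulfonamide of compound 2 but alters the group on the sulfonyl sulfur: amino in place of methyl on a sulfonyl sulfur. Going by the values given here, no measured step changes this position; the one measured step, an 80-fold lower number from compound 1 to compound 2 (1.90 log units; beyond the scatter), concerns a different exchange on the amine nitrogen and only shows that a sulfonamide at this place is well tolerated. The exchange is counted as a single heavy atom, so compound 3 is expected to stay near compound 2 in this assay, with a 2.0-fold higher number from compound 2 to compound 3 (0.30 log units; within the scatter) within the scatter. Compound 3 is thus estimated at 0.4 nM, between 0.1 nM and 1.6 nM.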

Compound 3, inhibition constant: 0.126 nM
Compound 3: middle estimate off by 3.2-fold (0.50 log units), on the high side, within the range that was stated.
By their numbers in this assay, from the lowest: compounds 3 and 2 (each within the scatter of the next); then compound 1.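

In this assay, amino in place of methyl on a sulfonyl sulfur gives a 1.6-fold lower number from compound 2 to compound 3 (0.20 log units; within the scatter) and so shows that this position takes either group, with no difference that stands out from the scatter. The large step away from the (1H-imidazol-2-yl)carbonyl group on the amine nitrogen also holds for sulfamoyl, at a 130-fold lower number from compound 1 to compound 3 (2.10 log units; beyond the scatter) in the same assay, so it is not confined to methylsulfonyl. Nothing available explains either step.

The compounds shown leave open whether a larger group on the sulfonyl sulfur, such as ethyl, dimethylamino or phenyl, would stay level with compound 2 and compound 3 in this assay as well. They also leave open how an acetyl group on the amine nitrogen would compare with these sulfonyl groups.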